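Ester for methyl on the benzyl group of a hydrolase inhibitor

A few compounds are considered here, and "the series" means these few. Any claim that something is new, unique, unknown or untested is made for them only; others in the source may bear on it.

These compounds share one core and differ only in the substituted benzyl group carried on the ring nitrogen. Compound 1 `O=c1c2cnn(-c3ccc(F)cc3)c2ncn1CC1(O)CCN(Cc2ccc(F)cc2)CC1` carries a 4-fluorobenzyl group, but in an assay on Sf21 cells for inhibition of ubiquitin carboxyl-terminal hydrolase 7 (Homo sapiens), read by spectrophotometry, with stated times of 30 min and 2 h (a higher number here means a weaker inhibitor, a lower number a stronger inhibitor), compound 1 gives "not determined" (no result reported), so no number was reported for it. Compound 2 `N#Cc1ccccc1CN1CCC(O)(Cn2cnc3c(cnn3-c3ccc(F)cc3)c2=O)CC1` carries a 2-cyanobenzyl group, and in this assay compound 2 gives 8100 nM, a weak result. Compound 3 `Cc1ccccc1CN1CCC(O)(Cn2cnc3c(cnn3-c3ccc(F)cc3)c2=O)CC1` carries a 2-methylbenzyl group; in this assay compound 3 gives "not determined" (no result reported), so it stands without a measured place, and with two of three entries lacking a number the picture for this small set rests on compound 2 alone.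

Compound 4 `COC(=O)c1ccc(CN2CCC(O)(Cn3cnc4c(cnn4-c4ccc(F)cc4)c3=O)CC2)cc1` differs from compound 3 by 4-(methoxycarbonyl)phenyl in place of 2-methylphenyl on a saturated chain carbon bound to an amine nitrogen in a ring. Going by the values given here, since no step between measured compounds is known, the size of this step cannot be read from the data; the one measured neighbour, compound 2, suggests that variations on this benzyl group give weak inhibition, and nothing here argues for a change beyond the scatter in either direction. Compound 4 is therefore expected to be a weak inhibitor, with an estimated value of 9000 nM and a plausible range from 2500 nM to 35000 nM.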

Compound 4, half-maximal inhibitory concentration: 4500 nM
Estimate against measurement, compound 4: 2.0-fold (0.30 log units) above; the measured number falls inside the stated range.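

With compound 4, a second number joins compound 2 in this assay, and the step reads a 1.8-fold lower number from compound 2 to compound 4 (0.26 log units; within the scatter). A 2-cyanophenyl and a 4-(methoxycarbonyl)phenyl on this saturated chain carbon thus give values that cannot be told apart, although the ester-bearing group is the larger of the two by heavy atoms, so among the two compounds with numbers, this exchange leaves the result within the usual scatter of the assay. Nothing shown here offers a measured explanation for the two values lying so close together.

On these data alone, the step named in the title, from the 2-methylphenyl group of compound 3 to the ester of compound 4, cannot be read, and neither can any step involving compound 1, as neither compound has a number, so the effect of the ester against methyl remains unknown. Also open, as far as these compounds go, is whether a different kind of group on this benzyl ring, such as a carboxylic acid or an amine, would shift the value beyond the scatter or leave it where these two compounds stand.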